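Ring amine methylation on two cores: working notes

This account rests on a few compounds, and the source may have more. Where it says the series, first, only, none or still open, it means among the compounds named here.

Measured compounds and their numbers:
compound 1 `CCn1cc(-c2nc3ccccc3s2)c(=O)c2cc(F)c(N3CCNCC3)cc21` — 28700 nM
compound 2 `CCn1cc(-c2nc3ccccc3s2)c(=O)c2cc(F)c(N3CCN(C)CC3)cc21` — 19000 nM
compound 3 `CCn1cc(-c2nc3ccc([N+](=O)[O-])cc3[nH]2)c(=O)c2cc(F)c(N3CCNCC3)cc21` — 1100 nM

All numbers come from a functional assay on KB cells (Homo sapiens) for cytotoxicity, read by MTT assay, with a stated time of 48 h; on this read-out higher numbers stand for weaker inhibition and lower numbers for stronger inhibition. Compound 1 and compound 2 share one core and differ only by methyl in place of hydrogen on an amine nitrogen in a ring. This change gives a 1.5-fold lower number from compound 1 to compound 2 (0.18 log units; within the scatter), so within this pair the methyl on the ring amine leaves the number essentially where it was.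

Compound 3 sits on a different core. The difference between the core of compound 3 and the core of compound 1 is not broken down here. In this assay compound 3 gives the lowest of the three numbers; its gaps to compound 2 and to compound 1 are both beyond the scatter, so on this read-out compound 3 is the strongest of the three measured compounds.

Compound 4 `CCn1cc(-c2nc3ccc([N+](=O)[O-])cc3[nH]2)c(=O)c2cc(F)c(N3CCN(C)CC3)cc21` has not yet been measured. It differs from compound 3 by methyl in place of hydrogen on an amine nitrogen in a ring, the same change, at the same place of the same six-membered ring, as that from compound 1 to compound 2. Going by the values given here, the only measured instance of this change is a 1.5-fold lower number from compound 1 to compound 2 (0.18 log units; within the scatter), and the step from compound 3 to compound 4 is expected to be of that size, namely a 1.4-fold lower number from compound 3 to compound 4 (0.14 log units; within the scatter). Whether the change behaves alike on the core of compound 3 is not shown by any measured pair, so the range is kept wide. Compound 4 is estimated at 800 nM in this assay, with an expected range from 350 nM to 2000 nM.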

Compound 4, half-maximal inhibitory concentration: 2500 nM
Compound 4: middle estimate off by 3.1-fold (0.49 log units), on the low side; the whole stated range lies below it.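

In this assay, methyl in place of hydrogen on the ring amine gives a 2.3-fold higher number from compound 3 to compound 4 (0.36 log units; beyond the scatter), so on this core the change costs a modest amount of inhibition, while on the core of compound 1 it left the number essentially where it was; the two steps differ: the same change on two cores in this assay, a 1.5-fold lower number (0.18 log units; within the scatter) from compound 1 to compound 2 and a 2.3-fold higher number (0.36 log units; beyond the scatter) from compound 3 to compound 4, 3.4-fold (0.54 log units) apart, beyond the scatter of two such steps

For this series, then, the step from piperazin-1-yl to 4-methylpiperazin-1-yl read on one core cannot simply be carried to the other, and its size on a new core has to be measured rather than assumed. Going by these compounds alone, this rests on only two pairs, so it does not show which part of the difference between the two cores sets the gap, how the change would behave on any third core, or that the change has any general direction.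

On these data alone, it remains open whether an ethyl group or a longer chain on the same ring nitrogen would follow the methyl step on each core or part further between them. As far as these compounds go, it also remains open whether a core carrying an amine in place of the nitro group of compound 3 would respond to the methyl as the core of compound 1 does or as the core of compound 3 does.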